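The source may report more compounds than this note shows. Statements on the series, on what has been measured and on what is new or still open speak of the compounds shown alone.

Compound 1 `CN1CCN(c2ccc3[nH]nc(S(=O)(=O)c4ccccc4Cl)c3c2)CC1` gives 101 nM in a functional assay on HeLa cells for antagonist activity at 5-hydroxytryptamine receptor 6 (Homo sapiens); on this read-out higher numbers stand for weaker inhibition and lower numbers for stronger inhibition. Compound 2 `CN1CCN(c2ccc3[nH]nc(S(=O)(=O)c4c(Cl)cccc4Cl)c3c2)CC1` gives 40 nM in this assay, and the step of a 2.5-fold lower number from compound 1 to compound 2 (0.40 log units; beyond the scatter) shows that adding a chloro on the aromatic carbon moved the number down modestly. Compound 2 therefore stands lowest of the two measured numbers, with compound 1 its nearest neighbour.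

Compound 3 `CN1CCN(c2ccc3[nH]nc(S(=O)(=O)c4ccc(F)cc4)c3c2)CC1` carries 4-fluorophenyl in place of 2,6-dichlorophenyl on a sulfonyl sulfur. For the measured compounds named here, the only measured step that bears on this, the chloro addition from compound 1 to compound 2, runs opposite to the present change, in which the chloro groups leave; the fluorine of 4-fluorophenyl has no measured counterpart. Compound 3 is thus expected to rise beyond compound 1, by an estimated 4.3-fold higher number from compound 2 to compound 3 (0.63 log units; beyond the scatter), with the unknown fluorine widening the range. Compound 3 is estimated at 170 nM, between 60 nM and 480 nM.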

Compound 3, half-maximal inhibitory concentration: 467 nM
The estimate for compound 3 lay 2.7-fold (0.44 log units) below the measured number; measured number inside the range.
By their numbers in this assay, from the lowest: compound 2; then compound 1; then compound 3.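

The change at the sulfonyl sulfur now has a measured size: in this assay, 4-fluorophenyl in place of 2,6-dichlorophenyl gives a 12-fold higher number from compound 2 to compound 3 (1.07 log units; beyond the scatter), a large step, and in place of 2-chlorophenyl it gives a 4.6-fold higher number from compound 1 to compound 3 (0.66 log units; beyond the scatter), a modest one. The group that leaves and the group that enters are each one six-membered aromatic ring of carbon only, so the number at this position moves widely even when only the substituents on that ring differ. Nothing available explains why the number moves in this way.

Each of these steps removes chloro and brings in fluorine at once, and the compounds shown do not separate the two changes. Also open, from the compounds shown here alone, is how an unsubstituted phenyl, or a phenyl carrying a methoxy or a nitrile, would read in this assay.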